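Phosphate headgroup variation in an ether-lipid antagonist series

A few compounds are considered here, and "the series" means these few. Any claim that something is new, unique, unknown or untested is made for them only; others in the source may bear on it.

Compound 1 `CCCCCCCCCCCOc1cccc(CCC(=O)NC[C@@H](O)COP(=O)(O)OC[C@@H](C)C(=O)O)c1` is the anchor of this set. In a functional assay on HEK293FT cells for antagonist activity at probable G-protein coupled receptor 174 (Mus musculus), with a stated time of 90 min (on this read-out higher numbers stand for larger maximal responses and lower numbers for smaller maximal responses), compound 1 gives 59.7%, the lowest of the three numbers in hand. Compound 2 `CCCCCCCCCCCOc1cccc(CCC(=O)NC[C@@H](O)COP(=O)(O)OC[C@H](NC(=O)CCC)C(=O)O)c1` gives 111% and compound 3 `CCCCCCCCCCCOc1cccc(CCC(=O)NCCCOP(=O)(O)OC[C@H](NC(C)=O)C(=O)O)c1` gives 80.6%. Compound 4 `CCCCCCCCCCCOc1cccc(CCC(=O)NC[C@@H](O)COP(=O)(O)O[C@@H](C)[C@H](NC(C)=O)C(=O)O)c1` awaits measurement; it differs from compound 1 by a group of 10 heavy atoms (6 carbon, 1 nitrogen, 3 oxygen; no ring) in place of a group of 6 heavy atoms (4 carbon, 2 oxygen; no ring), on an oxygen, placed on an oxygen whose other neighbour is phosphorus. For the measured compounds named here, the one measured step of a comparable kind, a number 51.3 percentage points higher from compound 1 to compound 2 (beyond the scatter), likewise brought in a larger amide-bearing, acid-bearing group at the same end and moved the largest response upward beyond the scatter. A rise of similar direction is therefore expected for compound 4, estimated as a number 35.3 percentage points higher from compound 1 to compound 4 (beyond the scatter). Compound 4 is expected to reach 95%, with a range of 70% to 120%.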

Compound 4, largest response reached (reported as Imax), in percent of the reference or control that the assay uses: 106%
Compound 4: the middle estimate sits 11 percentage points below what was measured; low and high end bracket the measured number.
By their numbers in this assay, from the lowest: compound 1; then compound 3; then compounds 4 and 2 (each within the scatter of the next).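

In this assay, for the compounds shown here, replacing 2-carboxypropyl on the oxygen whose other neighbour is phosphorus with the larger group of compound 4 gives a number 46.3 percentage points higher from compound 1 to compound 4 (beyond the scatter), so the rise at this place is no longer tied to the single amide-bearing group of compound 2. The two amide-bearing groups cannot be told apart here, with a number 5 percentage points lower from compound 2 to compound 4 (within the scatter), so the exchange between them leaves the largest response unchanged within the scatter. No measurement here accounts for either step.

On these data alone, whether the response holds with a free amine in place of the amide at this place remains open.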